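A Shorter Side Chain on the Shared Core

The compounds below may be only part of what the source reports. "The series", "measured", "known", "first", "only" and "open" are said of these compounds alone.

Measured so far in a functional assay (trachea) with Cavia porcellus as the target; a higher number here means that more compound is needed for the effect, a lower number that less compound is needed
- compound 1 `CCCn1c(=O)n(CCC(=O)O)c(=O)c2[nH]cnc21` gives 21200 nM
- compound 2 `CCCn1c(=O)n(CCC(N)=O)c(=O)c2[nH]cnc21` gives 13100 nM
- compound 3 `CCCn1c(=O)n(CCC(C)=O)c(=O)c2[nH]cnc21` gives 3500 nM

Compound 3 stands lowest of the three in this assay. Compound 4 `CCCn1c(=O)n(C)c(=O)c2[nH]cnc21` carries hydrogen in place of 2-oxopropyl on a saturated chain carbon bound to an aromatic nitrogen. The measured steps change only the group on a carbonyl carbon: one stayed within the scatter (a 1.6-fold lower number from compound 1 to compound 2 (0.21 log units; within the scatter)), and two went beyond it (a 3.7-fold lower number from compound 2 to compound 3 (0.57 log units; beyond the scatter)) (a 6.1-fold lower number from compound 1 to compound 3 (0.78 log units; beyond the scatter)). None removes the chain, so they are only loose guides. A modest rise of similar size is therefore expected (a 2.3-fold higher number from compound 3 to compound 4 (0.36 log units; beyond the scatter)). For compound 4 the estimated value is 8000 nM, with an expected range from 2500 nM to 25000 nM.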

Compound 4, half-maximal effective concentration: 1600 nM
Estimate against measurement, compound 4: 5.0-fold (0.70 log units) above, and the stated range ends above it.
By their numbers in this assay, from the lowest: compound 4; then compound 3; then compounds 2 and 1 (each within the scatter of the next).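

With hydrogen in place of 2-oxopropyl, carbamoylmethyl or carboxymethyl on a saturated chain carbon bound to an aromatic nitrogen, the number in this assay falls every time (a 2.2-fold lower number from compound 3 to compound 4 (0.34 log units; beyond the scatter)) (an 8.2-fold lower number from compound 2 to compound 4 (0.91 log units; beyond the scatter)) (a 13-fold lower number from compound 1 to compound 4 (1.12 log units; beyond the scatter)). At this position, then, none of the three carbonyl-bearing chains is needed for the effect, and the bare methyl of compound 4 stands below them all. Nothing available explains this result. The compounds shown leave open how a plain ethyl or longer alkyl chain, or a chain ending in an amine, would behave here.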